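This account rests on a few compounds, and the source may have more. Where it says the series, first, only, none or still open, it means among the compounds named here.

Of the compounds shown here, two built on a shared core have so far been tested in a functional assay on HeLa cells (Homo sapiens) for antiproliferative activity, read by CCK-8 assay, with a stated time of 48 h; on this read-out higher numbers stand for weaker inhibition and lower numbers for stronger inhibition. Compound 1 `COc1ccc(/C=C\c2cc(OC)c(OC)c(OC)c2)cc1OCc1ccc(CN2CCCCC2C(=O)NCCNC(=O)OC(C)(C)C)cc1` carries a long side chain ending in a carbamate; in this assay compound 1 gives 2000 nM. Compound 2 `COc1ccc(/C=C\c2cc(OC)c(OC)c(OC)c2)cc1OCc1ccc(CN2CC[C@H](C(=O)O)C2)cc1` carries instead a 3-carboxypyrrolidin-1-yl group on a saturated chain carbon bound to an aromatic carbon. In this assay compound 2 reports only > 10000 nM, which is a limit of the measurement and not a number. Compound 2 thus stands at the limit of > 10000 nM in this assay, at which 1 of the 2 values shown sits, so its true value is not pinned down.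

Compound 3 `COc1ccc(/C=C\c2cc(OC)c(OC)c(OC)c2)cc1OCc1ccc(CN[C@H](C(=O)O)[C@@H](C)O)cc1` has not yet been measured. It differs from compound 2 in one place: (1-carboxy-2-hydroxypropyl)amino in place of 3-carboxypyrrolidin-1-yl on a saturated chain carbon bound to an aromatic carbon. The ring is opened, a hydroxyl group is added and the carboxylic acid is kept. Since compound 2 already sits at a limit, the step that the limit leaves unreadable from compound 2 to compound 3 is expected to be small, with no clear direction beyond the usual scatter. Compound 3 is therefore expected to land near 15000 nM, within a range from 5000 nM to 50000 nM, and it may well again return only a limit.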

Compound 3, half-maximal inhibitory concentration: > 10000 nM
Compound 3 was reported as a limit; the forecaster's own chance of this, stated with the estimate: 65%; the middle value is on the limit's open side.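

Among these compounds, compound 2 and compound 3 both return only a limit of the measurement, so no step between them can be read: the limit of > 10000 nM in this assay, at which 2 of the 3 values shown sit. Going by these compounds, what stays open is whether the (1-carboxy-2-hydroxypropyl)amino group and the 3-carboxypyrrolidin-1-yl group differ at all in this measurement, and by how much, since neither compound's true value is pinned down.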